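Cytotoxicity notes on a vinyl sulfone amide series

A few compounds are considered here, and "the series" means these few. Any claim that something is new, unique, unknown or untested is made for them only; others in the source may bear on it.

Measured so far:
compound 1 `CC(=O)N(Cc1ccccc1C(=O)N[C@H](/C=C/S(=O)(=O)c1ccccc1)CCc1ccccc1)C(C)=O`: 36000 nM
compound 2 `O=C(NCc1ccccc1C(=O)N[C@H](/C=C(\F)S(=O)(=O)Oc1ccccc1)CCc1ccccc1)c1ccncc1`: > 100000 nM
compound 3 `O=C(NCc1ccccc1C(=O)N[C@H](/C=C(\F)S(=O)(=O)c1ccccc1)CCc1ccccc1)c1ccccc1`: 43000 nM

In a toxicity assay on J774.1 cells (Mus musculus) for cytotoxicity, read by MTT assay, with a stated time of 48 h (a higher number here means that more compound is tolerated, a lower number that less compound is tolerated), compound 1 gives 36000 nM and compound 3 gives 43000 nM; these two sit within the scatter of each other, so no order between them is claimed. Compound 2 returns only a limit of the assay, > 100000 nM. the limit of > 100000 nM in this assay, at which 1 of the 3 values shown sits, describes that outcome, which is a limit and not a number.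

Compound 4 `O=C(NCc1ccccc1C(=O)N[C@H](/C=C/S(=O)(=O)c1ccccc1)CCc1ccccc1)c1cccc(O)c1` has not been measured. It differs from compound 1 by ((3-hydroxyphenyl)carbonyl)amino in place of diacetylamino on a saturated chain carbon bound to an aromatic carbon. With compound 3 at 43000 nM lying alongside compound 1, the step is expected to stay small and within the scatter, as a 1.3-fold higher number from compound 1 to compound 4 (0.10 log units; within the scatter). Compound 4 is therefore estimated at 45000 nM, with a range from 20000 nM to 100000 nM.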

Compound 4, half-maximal cytotoxic concentration: 36000 nM
Compound 4: the middle estimate sits 1.3-fold (0.10 log units) above what was measured, within the range that was stated.
By their numbers in this assay, from the lowest: compounds 1, 4 and 3 (each within the scatter of the next). At a limit, above all of these: compound 2.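

In this assay, the change to ((3-hydroxyphenyl)carbonyl)amino in place of diacetylamino gives no change at the digits printed from compound 1 to compound 4 (within the scatter) on a saturated chain carbon bound to an aromatic carbon. For the compounds shown here, the earlier compounds held no pair differing in one place, so this is the first readable step: here a six-membered aromatic ring and hydrogen-bond donors enter without a shift in the number. No measured property on hand accounts for this step.

Still open, from the compounds shown here alone, is whether a basic amine or a carboxylic acid in this place, on the core of compound 1, would leave the number as it stands.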